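This account rests on a few compounds, and the source may have more. Where it says the series, first, only, none or still open, it means among the compounds named here.

Compound 1 `CSc1cc(C)nc(Cl)c1NC(=O)N(Cc1ccc(Oc2ccc(F)cc2)cc1)C1CCCCCC1` gives 0.022 mg/kg
Compound 2 `Cc1cc(S(C)(=O)=O)c(NC(=O)N(Cc2ccc(Oc3ccc(F)cc3)cc2)C2CCCCCC2)c(Cl)n1` gives > 0.1 mg/kg as a limit

In a functional assay on the whole organism with Rattus norvegicus as the target (a higher number here means that more compound is needed for the effect, a lower number that less compound is needed), compound 2 gives > 0.1 mg/kg as a limit and not a number. Compound 3 `Cc1cc(C)c(NC(=O)N(Cc2ccc(Oc3ccc(F)cc3)cc2)C2CCCCCC2)c(C)n1` differs from compound 2 on an amide-type nitrogen, where 2,4,6-trimethylpyridin-3-yl enters (a group of 9 heavy atoms (8 carbon, 1 nitrogen; one six-membered aromatic ring with 1 hetero atom) in place of a group of 12 heavy atoms (7 carbon, 1 nitrogen, 2 oxygen, 1 sulfur, 1 chlorine; one six-membered aromatic ring with 1 hetero atom), on an amide-type nitrogen). For the measured compounds named here, compound 3 carries no methylsulfonyl, and the one measured step that bears on this is (an at least 4.5-fold higher number from compound 1 to compound 2 (0.65 log units; beyond the scatter)) where that group took the place of methylsulfanyl, so a lower number is expected. Going by the values given here, no measured step covers the entering group itself, so the size stays uncertain. The expected change is modest (an at least 2.0-fold lower number from compound 2 to compound 3 (0.30 log units; that floor lies within the scatter)). Compound 3 is estimated at 0.05 mg/kg (range 0.012 mg/kg to 0.2 mg/kg).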

Compound 3, dose for half-maximal effect: 0.044 mg/kg
Compound 3: middle estimate off by 1.1-fold (0.06 log units), on the high side; measured number inside the range.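

In this assay, putting 2,4,6-trimethylpyridin-3-yl on the amide-type nitrogen gives an at least 2.2-fold lower number from compound 2 to compound 3 (0.35 log units; beyond the scatter), so a ring without methylsulfonyl or chlorine still works here. Set against the ring carrying methylsulfanyl and chlorine, the same group gives a 2.0-fold higher number from compound 1 to compound 3 (0.30 log units; within the scatter), so methyl groups serve about as well and neither compound can be ranked above the other. Compound 2 has only a limit, not a number: the limit of > 0.1 mg/kg in this assay, at which 1 of the 3 values shown sits.

Going by these compounds, each step swaps the whole ring group, so how much each single ring substituent contributes stays open. Also open, on these data alone, is how an amine or a carboxylic acid on this ring would fare.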